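Swapping the Amine Ring and Watching Cell Tolerance

A few compounds are considered here, and "the series" means these few. Any claim that something is new, unique, unknown or untested is made for them only; others in the source may bear on it.

Compound 1 `Cc1nc(C(NC(=O)C(=O)Nc2ccc(Cl)cc2)C2CCCCN2C)sc1CCO` carries a 1-methylpiperidin-2-yl group on a saturated chain carbon bound to an amide-type nitrogen and an aromatic carbon. For the measured compounds named here, in an ADME assay on MT2 cells (Homo sapiens) for cytotoxicity, read by XTT assay, with a stated time of 4 days (a lower number here means that less compound is tolerated, a higher number that more compound is tolerated), compound 1 gives 88000 nM, the higher of the two numbers measured so far. Its nearest neighbour is compound 3 `Cc1nc(C(NC(=O)C(=O)Nc2ccc(Cl)cc2)C2CCCN2)sc1CO`, which in this assay gives 45000 nM; the gap between these two lies within the usual scatter, so the two numbers cannot be ranked. Compound 2 `Cc1nc(C(NC(=O)C(=O)Nc2ccc(C(F)(F)F)cc2)C2CCCCN2)sc1CO` gives no number at all in this assay but only a limit, > 75500 nM, and that limit is the limit of > 75500 nM in this assay, at which 1 of the 3 values shown sits.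

The step under study leads to compound 4 `Cc1nc(C(NC(=O)C(=O)Nc2ccc(Cl)cc2)C2CCCNC2)sc1CCO`, which differs from compound 1 in one place: piperidin-3-yl in place of 1-methylpiperidin-2-yl on a saturated chain carbon bound to an amide-type nitrogen and an aromatic carbon. Going by the values given here, no step between two measured compounds is available to calibrate what such a swap does in this assay. Across the three compounds shown, the numbers and the limit all sit in the same broad region, so the change is expected to stay within the scatter, with no clear direction. The expected step of a 1.3-fold lower number from compound 1 to compound 4 (0.10 log units; within the scatter) is therefore estimated to be small. Compound 4 is expected to give about 70000 nM in this assay, most likely between 30000 nM and 160000 nM.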

Compound 4, half-maximal cytotoxic concentration: > 78500 nM
Compound 4 ended at the assay's limit; the forecaster's own chance of this, stated with the estimate: 25%; middle value at least 1.1-fold (0.04 log units) from the limit.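

In this assay compound 4 gives > 78500 nM as a limit and not as a number. No size or direction can be read for the swap from compound 1 to compound 4: the limit of > 78500 nM in this assay, at which 1 of the 4 values shown sits. The compounds shown leave open whether piperidin-3-yl in place of 1-methylpiperidin-2-yl changes cell tolerance at all.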